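A few compounds are considered here, and "the series" means these few. Any claim that something is new, unique, unknown or untested is made for them only; others in the source may bear on it.

Working notes on the series. In an ADME assay on HEL cells (Homo sapiens) for cytotoxicity, with a stated time of 3 days (a lower number here means that less compound is tolerated, a higher number that more compound is tolerated), compound 1 `COc1cccc(-c2cc(C)c3ncc(CSCCc4ccccc4)n3c2)c1` gives 36 ug/mL and stands highest of the two numbers shown. The nearest is compound 3 `COc1ccc(-c2cc(C)cn3c(CSCCc4ccccc4)cnc23)cc1`, which gives 19.6 ug/mL in this assay, a gap within the scatter. Compound 2 `COc1cccc(-c2cc(C)cn3c(CSCCc4ccccc4)cnc23)c1` returns > 50 ug/mL in this assay; this is the limit of > 50 ug/mL in this assay, at which 1 of the 3 values shown sits, not a number. Among the measured compounds shown here, the one measured step, an at least 2.5-fold lower number from compound 2 to compound 3 (0.40 log units; beyond the scatter), concerns where the methoxy sits and not its replacement, so it does not bear on the change at hand. Compound 4 `Cc1cc(-c2cccc([N+](=O)[O-])c2)cn2c(CSCCc3ccccc3)cnc12` differs from compound 1 by nitro in place of methoxy on an aromatic carbon. For the measured compounds named here, with no comparable step measured, no step beyond the scatter is expected. Compound 4 is therefore expected near 30 ug/mL, with a range from 12 ug/mL to 75 ug/mL. This estimate means a step of a 1.2-fold lower number from compound 1 to compound 4 (0.08 log units; within the scatter).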

Compound 4, half-maximal cytotoxic concentration: 43 ug/mL
Compound 4: the middle estimate sits 1.4-fold (0.16 log units) below what was measured; low and high end bracket the measured number.
By their numbers in this assay, from the lowest: compounds 3, 1 and 4 (each within the scatter of the next, the first and the last beyond it). At a limit, above all of these: compound 2.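

In this assay, the change from 3-methoxyphenyl to 3-nitrophenyl gives a 1.2-fold higher number from compound 1 to compound 4 (0.08 log units; within the scatter), so nitro and methoxy are not told apart on this aromatic carbon, meta to a large group. The earlier compounds shown here showed only a move of the methoxy, not a replacement of it. Nothing shown accounts for this step. Still open, from the compounds shown here alone, is whether an amine or a carboxylic acid on this carbon would also stay within the scatter of compound 1. Going by these compounds, a longer alkoxy chain in place of methoxy is equally open.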